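A few compounds are considered here, and "the series" means these few. Any claim that something is new, unique, unknown or untested is made for them only; others in the source may bear on it.

Measured compounds:
compound 1, `NCCCCN(C[C@H]1Cc2cccnc2CN1)[C@H]1CCCc2cccnc21`, 2 nm/s
compound 2, `NC/C=C/CN(C[C@H]1Cc2ncccc2CN1)[C@H]1CCCc2cccnc21`, 2 nm/s

Two compounds share a common core and have been run in an ADME assay for permeability, using PAMPA, with a stated time of 4 h, at pH 5.5; a higher number here means that the compound crosses the layer faster, a lower number that the compound crosses the layer more slowly. Compound 1 has the structure `NCCCCN(C[C@H]1Cc2cccnc2CN1)[C@H]1CCCc2cccnc21` and gives 2 nm/s in this assay. Compound 2 has the structure `NC/C=C/CN(C[C@H]1Cc2ncccc2CN1)[C@H]1CCCc2cccnc21` and gives 2 nm/s in this assay. Compound 2 therefore stands level with compound 1 at the digits reported, and its nearest neighbour in value is compound 1, with no change at the digits reported, within the usual scatter.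

Compound 3, with the structure `c1cnc2c(c1)CN[C@@H](CN(CCCC1CCNCC1)[C@H]1CCCc3cccnc31)C2`, has not yet been measured in this assay. It differs from compound 2 in one place: 2-(piperidin-4-yl)ethyl in place of 3-aminoprop-1-en-1-yl on a saturated chain carbon bound to an amine nitrogen. Within the data shown here, no step between measured compounds is available for this kind of change, so the two reported values alone guide what is expected. Both sit at the same low level. Compound 3 is expected to remain in that low region, and the step from compound 2 to compound 3 is expected to be a 1.5-fold higher number from compound 2 to compound 3 (0.18 log units; within the scatter), not beyond the scatter. For compound 3 the estimated value in this assay is 3 nm/s, with a range from 1 nm/s to 10 nm/s.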

Compound 3, apparent permeability: 14 nm/s
Compound 3: the middle estimate sits 4.7-fold (0.67 log units) below what was measured; measured number above the stated range.
By their numbers in this assay, from the lowest: compounds 1 and 2 (each within the scatter of the next); then compound 3.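

In this assay, the substituent on a saturated chain carbon bound to an amine nitrogen turns out to matter: placing 2-(piperidin-4-yl)ethyl where 3-aminoprop-1-en-1-yl stood gives a 7.0-fold higher number from compound 2 to compound 3 (0.85 log units; beyond the scatter), whereas the two earlier compounds, sitting level, gave no sign that the read-out could move at all. The step came with no change in the counts of hydrogen-bond donors and acceptors and with no net charge on either group, while the entering group brings more heavy atoms, a six-membered non-aromatic ring and no double bond outside aromatic rings. No measurement shown here explains why the number rose.

This single step changes chain length, ring content and the double bond together, so the compounds shown cannot assign the rise to any one of these features. Going by these compounds, it also remains open whether a simple saturated chain ending in a primary amine on the same core would reach a similar number, or whether a morpholine ring in place of the piperidine would keep the rise.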